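Swapping the Aryl Group on a Ring Nitrogen

The source may hold more compounds than are shown below. What is called first, only, known or untested is meant among the compounds shown, and "the series" means these compounds.

Measured compounds:
compound 1 `O=C(Nc1ccc(O)c(C(=O)O)c1)c1ccc(/C=C2\SC(=S)N(c3ccccc3)C2=O)cc1` — > 10000 nM in an assay on isolated protein for inhibition of Apoptosis regulator Bcl-2 (Homo sapiens), read by fluorescence polarization; on this read-out higher numbers stand for weaker inhibition and lower numbers for stronger inhibition
compound 2 `Cc1cccc(N2C(=O)/C(=C/c3ccc(OCc4ccc(C(=O)O)cc4)cc3)SC2=S)c1` — > 10000 nM in this assay

In this assay compound 1 gives > 10000 nM, which is a limit of the assay and not a number. Compound 2 gives > 10000 nM in this assay, again only a limit. Compound 2 therefore stands at the limit of > 10000 nM in this assay, at which 2 of the 2 values shown sit. For the measured compounds named here, both values shown are limits, so no step between measured compounds is available and no size of step has been seen so far.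

Compound 3 `O=C(O)c1ccc(COc2ccc(/C=C3\SC(=S)N(c4ccc(Br)cc4)C3=O)cc2)cc1` differs from compound 2 in one place: 4-bromophenyl in place of 3-methylphenyl on an amide-type nitrogen in a ring. Going by the values given here, since compound 2 sits at the limit, a change at the amide-type nitrogen in the ring gives no measured step to lean on. The expectation is a step from compound 2 to compound 3 of a step that the limit leaves unreadable from compound 2 to compound 3, which would be none beyond the scatter, leaving compound 3 at the limit as well. In this assay compound 3 is expected to give 15000 nM, with a range from 5000 nM to 50000 nM, most probably reported once more as a limit rather than a number.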

Compound 3, inhibition constant: 610 nM
Compound 3: middle estimate off by 25-fold (1.39 log units), on the high side; measured number below the stated range.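

In this assay, the group on the amide-type nitrogen in the ring turns out to matter: 4-bromophenyl in place of 3-methylphenyl gives an at least 16-fold lower number from compound 2 to compound 3 (1.21 log units; beyond the scatter). For the compounds shown here, the earlier compounds sat only at a limit and showed no readable effect of any change, whereas this swap, between two aryl groups with the same heavy-atom count and no hydrogen-bond donors or acceptors on either side, produces a step beyond the scatter and the first real number in the set. The step's size is only a lower bound, since one end of it is a limit and not a number: the limit of > 10000 nM in this assay, at which 2 of the 3 values shown sit.

The compounds shown do not separate the effect of the bromine from that of its place on the phenyl ring, as the two aryl groups differ in both the substituent and where it sits. They also leave open whether a chlorine, a trifluoromethyl or a methoxy group in place of the bromine would hold a measurable number in this assay, and whether the gain at this position carries over to other parts of the shared core.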